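Dibromo hydroxyphenyl hydrazone in a triazolylpyridine ether series

This account rests on a few compounds, and the source may have more. Where it says the series, first, only, none or still open, it means among the compounds named here.

Measured compounds:
Compound 1, `CN(C)CCn1cnnc1-c1cc(Oc2ccc(NC(=O)N/N=C/c3ccc(F)cc3Cl)cc2F)ccn1`, 720 nM
Compound 2, `CN(C)CCn1cnnc1-c1cc(Oc2ccc(NC(=O)N/N=C/c3cccc(Cl)c3Cl)cc2F)ccn1`, 72 nM
Compound 3, `CN(C)CCn1cnnc1-c1cc(Oc2ccc(NC(=O)N/N=C/c3ccc(O)c(F)c3)cc2F)ccn1`, 2620 nM

All three share one core and differ only in the aryl group on the carbon with a double bond to nitrogen. In a functional assay on NCI-H460 cells (Homo sapiens) for cytotoxicity, read by MTT assay, with a stated time of 72 h (a lower number here means a stronger inhibitor, a higher number a weaker inhibitor), compound 2 gives 72 nM, the lowest number of the three, and the step of a 10-fold lower number from compound 1 to compound 2 (1.00 log units; beyond the scatter) is beyond the scatter. Compound 3 stands highest: the step of a 3.6-fold higher number from compound 1 to compound 3 (0.56 log units; beyond the scatter) and the step of a 36-fold higher number from compound 2 to compound 3 (1.56 log units; beyond the scatter) both run upward, so compound 3 is the weakest of the measured set.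

Compound 4, `CN(C)CCn1cnnc1-c1cc(Oc2ccc(NC(=O)N/N=C/c3cc(Br)c(O)c(Br)c3)cc2F)ccn1`, has not yet been tested. Its difference from compound 3 is 3,5-dibromo-4-hydroxyphenyl in place of 3-fluoro-4-hydroxyphenyl on a carbon with a double bond to nitrogen. The steps bearing on it are the aryl exchanges already seen, where halogenated phenyl groups gave lower numbers than the hydroxy-bearing one, as in a 36-fold higher number from compound 2 to compound 3 (1.56 log units; beyond the scatter) and a 3.6-fold higher number from compound 1 to compound 3 (0.56 log units; beyond the scatter). Going by the values given here, no measured pair changes the ring in exactly this way, so the direction rests on analogy alone. A modest downward step is therefore expected in this assay, roughly a 2.9-fold lower number from compound 3 to compound 4 (0.46 log units; beyond the scatter), and compound 4 is estimated at 900 nM, with a range from 250 nM to 3200 nM.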

Compound 4, half-maximal inhibitory concentration: 3760 nM
For compound 4 the middle estimate is 4.2-fold (0.62 log units) below the measured one; measured number above the stated range.
By their numbers in this assay, from the lowest: compound 2; then compound 1; then compounds 3 and 4 (each within the scatter of the next).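

In this assay, exchanging the single fluorine of the 3-fluoro-4-hydroxyphenyl group for the two bromines of the 3,5-dibromo-4-hydroxyphenyl group leaves the read-out unresolved (a 1.4-fold higher number from compound 3 to compound 4 (0.16 log units; within the scatter)), so this halogen exchange on a ring that keeps its hydroxy group cannot be told from no change at all. The earlier compounds shown here left open whether any dihalogenated aryl group on the carbon with a double bond to nitrogen would give a low number, and compound 4 shows that this does not hold across the set: it carries two halogens, as compound 2 does, yet the step is large (a 52-fold higher number from compound 2 to compound 4 (1.72 log units; beyond the scatter)), and the step from the mixed chloro and fluoro group is modest (a 5.2-fold higher number from compound 1 to compound 4 (0.72 log units; beyond the scatter)). Among these four compounds, the two with a hydroxy group give the higher numbers and the two without one give the lower numbers, with no compound going against this, but no accompanying measurement bears on why.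

As far as these compounds go, it remains open whether the hydroxy group itself sets this division, which a methoxy group or an amine in its place could test. From the compounds shown here alone, it is equally open whether the split would persist with a hydroxy group added to the 2,3-dichlorophenyl group of compound 2.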